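Adding a Second Methyl to the Amide Aryl Ring

The source may hold more compounds than are shown below. What is called first, only, known or untested is meant among the compounds shown, and "the series" means these compounds.

Measured so far, in a functional assay on HCC1937 cells (Homo sapiens) for antiproliferative activity, read by CCK-8 assay, with a stated time of 72 h; on this read-out higher numbers stand for weaker inhibition and lower numbers for stronger inhibition:
compound 1 `O=C(Nc1cccc(-c2oc3cc(-c4ccc(F)cc4)ccc3c(=O)c2O)c1)c1ccc(F)cc1` gives 14200 nM
compound 2 `Cc1ccccc1C(=O)Nc1cccc(-c2oc3cc(-c4ccc(F)cc4)ccc3c(=O)c2O)c1` gives 9900 nM
compound 3 `Cc1cccc(C(=O)Nc2cccc(-c3oc4cc(-c5ccc(F)cc5)ccc4c(=O)c3O)c2)c1` gives 8030 nM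

Compound 3 has the lowest of the three numbers, yet its gaps to compound 2 and to compound 1 are within the scatter, so none of the three can be called stronger than another. Compound 4 `Cc1cc(C)cc(C(=O)Nc2cccc(-c3oc4cc(-c5ccc(F)cc5)ccc4c(=O)c3O)c2)c1` differs from compound 3 by methyl in place of hydrogen on an aromatic carbon. Among the compounds with values here, the steps that bear on this all change the same aryl group on the carbonyl carbon: a 1.4-fold lower number from compound 1 to compound 2 (0.16 log units; within the scatter), a 1.8-fold lower number from compound 1 to compound 3 (0.25 log units; within the scatter) and a 1.2-fold lower number from compound 2 to compound 3 (0.09 log units; within the scatter). Each stayed within the scatter, so one more methyl on that ring is expected to give no step beyond the scatter in this assay. Compound 4 is therefore estimated at 7000 nM, with a range of 3500 nM to 14000 nM. That estimate means a 1.1-fold lower number from compound 3 to compound 4 (0.06 log units; within the scatter).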

Compound 4, half-maximal inhibitory concentration: 4860 nM
For compound 4 the middle estimate is 1.4-fold (0.16 log units) above the measured one; low and high end bracket the measured number.
By their numbers in this assay, from the lowest: compounds 4, 3, 2 and 1 (each within the scatter of the next, the first and the last beyond it).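

In this assay the second methyl alone gives a 1.7-fold lower number from compound 3 to compound 4 (0.22 log units; within the scatter) and so cannot be called a gain on its own. Set against other aryl groups, however, the 3,5-dimethylphenyl group gives the only steps in this set that lie beyond the scatter, a 2.0-fold lower number from compound 2 to compound 4 (0.31 log units; beyond the scatter) and a 2.9-fold lower number from compound 1 to compound 4 (0.47 log units; beyond the scatter), and both are modest. No measurement shown here accounts for these steps. Still open, on these data alone, is whether an amine, a carboxylic acid or a longer chain in place of a methyl on this ring would shift the number further.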